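Allyl to Phenyl on the Triazole Nitrogen: Expected Edema Inhibition

This account rests on a few compounds, and the source may have more. Where it says the series, first, only, none or still open, it means among the compounds named here.

Of the compounds shown here, three sharing a triazole core have been tested in a functional assay on the whole organism (strain albino) for inhibition, with Rattus norvegicus as the target, read by paw edema, with a stated time of 2 h, at a dose of 0.28 mmol/kg by the oral route; a higher number here means more inhibition at the dose given (going by the name of the read-out), a lower number less inhibition. Compound 1 `C=CCn1c(SC/C(=N/O)c2ccccc2)nnc1-c1cc(OC)c(OC)c(OC)c1` gives 68%. Compound 2 `COc1cc(-c2nnc(SC/C(=N/O)c3ccccc3)n2-c2ccccc2)cc(OC)c1OC` gives 61%, and compound 3 `C=CCn1c(SCC(=O)c2ccccc2)nnc1-c1cc(OC)c(OC)c(OC)c1` gives 62%. The cores of compound 1 and compound 3 differ by a group of 8 heavy atoms (7 carbon, 1 oxygen; one six-membered aromatic ring of carbon only) in place of a group of 9 heavy atoms (7 carbon, 1 nitrogen, 1 oxygen; one six-membered aromatic ring of carbon only), on a saturated chain carbon bound to a sulfur; this gives a number 6 percentage points lower from compound 1 to compound 3 (within the scatter). The change from compound 1 to compound 2 is phenyl in place of allyl on an aromatic nitrogen, which produced a number 7 percentage points lower from compound 1 to compound 2 (within the scatter).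

Compound 4 `COc1cc(-c2nnc(SCC(=O)c3ccccc3)n2-c2ccccc2)cc(OC)c1OC` has not yet been measured in this assay. It differs from compound 3 by phenyl in place of allyl on an aromatic nitrogen. This is the same kind of change as that from compound 1 to compound 2, though the surroundings differ: in compound 3 the nitrogen is next to the ring atom that bears a (benzoylmethyl)sulfanyl group and next to the ring atom that bears a large group, whereas in compound 1 it is next to two ring atoms that each bear a large group.

Compound 4 is expected to give about 56%, between 44% and 68%. This estimate means a step of a number 6 percentage points lower from compound 3 to compound 4 (within the scatter), resting on the earlier step of the same kind, a number 7 percentage points lower from compound 1 to compound 2 (within the scatter), which lay within the scatter.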

Compound 4, a percentage reported as inhibition, in the whole organism at one dose (the size of the read-out at that dose, not a potency): 51%
For compound 4 the middle estimate is 5 percentage points above the measured one; measured number inside the range.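

In this assay, phenyl in place of allyl on the aromatic nitrogen gives a number 11 percentage points lower from compound 3 to compound 4 (beyond the scatter), and this step stands close to the earlier one: the same change on two cores in this assay, a number 7 percentage points lower (within the scatter) from compound 1 to compound 2 and a number 11 percentage points lower (beyond the scatter) from compound 3 to compound 4, 4 percentage points apart, within the scatter of two such steps. The change on the saturated chain carbon bound to a sulfur gives a number 10 percentage points lower from compound 2 to compound 4 (within the scatter), and it also carries over: the same change on two cores in this assay, a number 6 percentage points lower (within the scatter) from compound 1 to compound 3 and a number 10 percentage points lower (within the scatter) from compound 2 to compound 4, 4 percentage points apart, within the scatter of two such steps. Each change thus keeps its direction and a similar size on the two cores shown, but two cores cannot show that this would hold on any other core, and the numbers give no reason for either step.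

The compounds shown leave open how a propyl or a benzyl group on the aromatic nitrogen would read in this assay, which would help separate the effect of the double bond of allyl from that of the ring of phenyl. They also leave open what an amine or a carboxylic acid on the chain bound to the sulfur would do.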